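One Measured Anilinoquinazoline Cinnamamide and a Trimethoxyphenyl Analogue

The source may report more compounds than this note shows. Statements on the series, on what has been measured and on what is new or still open speak of the compounds shown alone.

compound 1 `COc1ccc(/C=C/C(=O)Nc2cc3c(Nc4ccc(F)c(Cl)c4)ncnc3cc2OC)c(OC)c1` — "not determined" (no result reported)
compound 2 `COc1cc(/C=C/C(=O)Nc2cc3c(Nc4ccc(F)c(Cl)c4)ncnc3cc2O[C@H]2CCOC2)cc(OC)c1O` — 27400 nM
compound 3 `COc1cc(/C=C/C(=O)Nc2cc3c(Nc4ccc(F)c(Cl)c4)ncnc3cc2OC)cc(OC)c1` — "not determined" (no result reported)

Three compounds sharing one core were examined in a functional assay on HeLa cells (Homo sapiens) for cytotoxicity, read by MTT assay, with a stated time of 72 h; a higher number here means a weaker inhibitor, a lower number a stronger inhibitor. For compound 1 and compound 3 no result was reported, so compound 2 stands alone with the only number shown; in this assay compound 2 gives 27400 nM, and with no second number there is nothing to rank it against.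

Compound 4 `COc1ccc(/C=C/C(=O)Nc2cc3c(Nc4ccc(F)c(Cl)c4)ncnc3cc2O[C@H]2CCOC2)c(OC)c1OC` is to be measured in this assay. It differs from compound 2 in one place: 2,3,4-trimethoxyphenyl in place of 4-hydroxy-3,5-dimethoxyphenyl on a double-bonded chain carbon bound to a double-bonded chain carbon. Among the measured compounds shown here, because no pair of measured compounds differs in a single place, no measured step exists to guide the expectation. The available change swaps one substituted phenyl for another on the same double-bonded chain carbon, and with only the value of compound 2 in hand, no shift beyond the usual scatter is expected for compound 4 in this assay. Compound 4 is therefore estimated at 25000 nM, with a range from 8000 nM to 80000 nM. The estimated step of a 1.1-fold lower number from compound 2 to compound 4 (0.04 log units; within the scatter) is expected to stay within the scatter of repeated measurements.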

Compound 4, half-maximal inhibitory concentration: 4830 nM
Beside the measured number, compound 4's estimate is 5.2-fold (0.71 log units) above it, and the stated range ends above it.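

In this assay, among the compounds shown here, placing 2,3,4-trimethoxyphenyl where 4-hydroxy-3,5-dimethoxyphenyl stood on a double-bonded chain carbon bound to a double-bonded chain carbon gives a 5.7-fold lower number from compound 2 to compound 4 (0.75 log units; beyond the scatter) and supplies the first measured step. For the compounds shown here, it shows that the read-out at this position depends on which substituted phenyl is attached, something the single earlier number could not show. No measurement shown here explains the shift.

The change replaces a group with 1 hydrogen-bond donor and 11 heavy atoms by one with 0 hydrogen-bond donors and 12 heavy atoms, and it also rearranges the substituents, so this one step cannot assign the shift to any single feature. The compounds shown also leave open how an amine, a carboxylic acid or a longer alkoxy chain on this phenyl would read out.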